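This account rests on a few compounds, and the source may have more. Where it says the series, first, only, none or still open, it means among the compounds named here.

Of the compounds shown here, two built on a shared core have been tested in a functional assay on Ehrlich cells (Mus musculus) for cytotoxicity, tested at 50 ug/mL; a lower number here means a weaker effect, a higher number a stronger effect of the compound at the concentration tested. Compound 1, `COc1cc(N2C(N)=C(C#N)C(/C=C/c3ccccc3)C3=C2CC(C)(C)CC3=O)cc(OC)c1OC`, carries a 2-phenylethenyl group on a saturated ring carbon, and in this assay compound 1 gives 30%. Compound 2, `COc1cc(N2C(N)=C(C#N)C(c3ccccc3O)C3=C2CC(C)(C)CC3=O)cc(OC)c1OC`, carries a 2-hydroxyphenyl in that place, and in this assay compound 2 gives 2%. Going by the values given here, the step between them was a number 28 percentage points lower from compound 1 to compound 2 (beyond the scatter), so compound 2 stands lowest of the two numbers, with compound 1 as its only and nearest neighbour.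

Compound 3, `COc1cc(N2C(N)=C(C#N)C(c3ccc(C)cc3)C3=C2CC(C)(C)CC3=O)cc(OC)c1OC`, has not yet been measured. It differs from compound 2 in one place: 4-methylphenyl in place of 2-hydroxyphenyl on a saturated ring carbon. The group that leaves holds one hydrogen-bond donor and one hydrogen-bond acceptor, the group that enters holds none. Among the compounds with values here, the single measured step, from compound 1 to compound 2, concerned a different exchange at the same saturated ring carbon and was of modest size, so it offers only a loose guide here. Nothing measured shows what the present exchange does. Compound 3 is therefore expected to sit near compound 2, perhaps somewhat higher, estimated at 12% within a wide range from 0% to 35%. The expected step of a number 10 percentage points higher from compound 2 to compound 3 (within the scatter) is thus small against the scatter.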

Compound 3, a percentage reported as activity, at one concentration (the size of the read-out at that concentration, not a potency): 60%
The estimate for compound 3 lay 48 percentage points below the measured number; measured number above the stated range.
By their numbers in this assay, from the lowest: compound 2; then compound 1; then compound 3.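

Swapping 2-hydroxyphenyl for 4-methylphenyl on this saturated ring carbon in this assay gives a number 58 percentage points higher from compound 2 to compound 3 (beyond the scatter), so this position can strongly change the read-out even when the two groups have the same count of 7 heavy atoms and each holds one six-membered aromatic ring of carbon only. The 4-methylphenyl group also stands apart from the 2-phenylethenyl group, with a number 30 percentage points higher from compound 1 to compound 3 (beyond the scatter), which places the 2-phenylethenyl compound between the two aromatic-ring groups and shows that an aromatic ring of this kind at this carbon can go with either the lowest or the highest of the three numbers. Nothing available gives a reason for these differences.

This exchange removes a hydroxyl group, adds a methyl group and also changes the place of the substituent on the aromatic ring, so the compounds shown cannot tell which of these matters; plain phenyl, 4-hydroxyphenyl and 2-methylphenyl would separate them. From the compounds shown here alone, how the position responds to quite different groups, such as 4-aminophenyl, 4-carboxyphenyl or a longer alkyl chain, also remains open.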